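The source may report more compounds than this note shows. Statements on the series, on what has been measured and on what is new or still open speak of the compounds shown alone.

Measured compounds:
Compound 1 `Cc1c(OCCCCOc2ccc(C(=O)O)c(Cl)c2)ccc(C(=O)CC(C)C)c1O` gives 49.5% in an assay on HEK293 cells for positive allosteric modulation of metabotropic glutamate receptor 3 (Rattus norvegicus), read by thallium flux, with a stated time of 2.5 min; a lower number here means a smaller maximal response, a higher number a larger maximal response.
Compound 2 `Cc1c(OCCCCOc2ccc(C(=O)O)c(Cl)c2)ccc(C(=O)CC2CCCC2)c1O` gives 40%.
Compound 3 `Cc1c(OCCCCOc2ccc(C(=O)O)c(Cl)c2)ccc(C(=O)CC(C)C)c1C` gives 12%.

Compound 1 stands highest of the three numbers. Its nearest neighbour is compound 2, as the step of a number 9.5 percentage points lower from compound 1 to compound 2 (within the scatter) shows, so these two cannot be told apart. The step of a number 37.5 percentage points lower from compound 1 to compound 3 (beyond the scatter) is large and sets compound 3 clearly apart.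

Compound 4 `Cc1c(OCCCCOc2ccc(F)c(C(=O)O)c2)ccc(C(=O)CC(C)C)c1O` is not yet measured. It differs from compound 1 in one place: 3-carboxy-4-fluorophenyl in place of 4-carboxy-3-chlorophenyl on an oxygen on a saturated carbon. Neither measured step bears on this change: one alters the saturated chain carbon bound to the carbonyl carbon, the other an aromatic carbon of the shared core, and both leave the 4-carboxy-3-chlorophenyl untouched. Nothing measured therefore speaks for a step in this assay beyond the scatter in either direction, but nothing rules one out. The account estimates that compound 4 reaches 42%, with a range from 22% to 60%. This estimate means a step of a number 7.5 percentage points lower from compound 1 to compound 4 (within the scatter), expected to stay near the value of compound 1.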

Compound 4, largest response reached (reported as percent of maximum), in percent of the reference or control that the assay uses: 81.7%
The estimate for compound 4 lay 39.7 percentage points below the measured number; measured number above the stated range.
By their numbers in this assay, from the lowest: compound 3; then compounds 2 and 1 (each within the scatter of the next); then compound 4.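

Among the compounds shown here, the aromatic group on an oxygen on a saturated carbon turns out to matter for the maximal response in this assay: the earlier compounds changed only other parts of the molecule, whereas replacing 4-carboxy-3-chlorophenyl with 3-carboxy-4-fluorophenyl gives a number 32.2 percentage points higher from compound 1 to compound 4 (beyond the scatter). The two groups match in everything counted except the halogen, so this large rise comes with a swap of chlorine for fluorine and a shift of the carboxy group, made together in one step. No measurement at hand explains the rise.

The compounds shown cannot separate the halogen swap from the carboxy shift, and a phenyl carrying the carboxylic acid with no halogen, or a tetrazole in its place, remains open. Also open, going by these compounds, is whether the rise carries over to the core of compound 3.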